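The source may hold more compounds than are shown below. What is called first, only, known or untested is meant among the compounds shown, and "the series" means these compounds.

Three compounds have numbers so far:

Compound 2, `CC(C)c1n[nH]c2c(NCc3ccc(-c4ccccn4)cc3)nc(SCC(O)CN)nc12`, gives 55 nM in a functional assay on HT cells (Homo sapiens) for antiproliferative activity, read by fluorescence, with a stated time of 72 h; on this read-out lower numbers stand for stronger inhibition of growth and higher numbers for weaker inhibition of growth.
Compound 3, `CC(C)c1n[nH]c2c(NCc3ccc(-c4ccccn4)cc3)nc(SCC3CNC(=O)O3)nc12`, gives 80 nM in this assay.
Compound 1, `CC(C)c1n[nH]c2c(NCc3ccc(-c4ccccn4)cc3)nc(SCC(O)C(F)(F)F)nc12`, gives 690 nM in this assay.

Compound 2 has the lowest of the three numbers. Its nearest neighbour is compound 3, and the step from compound 2 to compound 3 is within the scatter: a 1.5-fold higher number from compound 2 to compound 3 (0.16 log units; within the scatter). Its furthest neighbour is compound 1, and that step lies well beyond the scatter: a 13-fold lower number from compound 1 to compound 2 (1.10 log units; beyond the scatter). The third measured step, an 8.6-fold lower number from compound 1 to compound 3 (0.94 log units; beyond the scatter), is of similar size.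

Compound 4, `CC(C)c1n[nH]c2c(NCc3ccc(-c4ccccn4)cc3)nc(SC[C@H](O)CN)nc12`, has not yet been measured. It differs from compound 2 as follows: the two compounds have the same atoms and bonds; at least one stereo element is drawn with a configuration in one of them and without one in the other: 1 of 1 stereo elements differ; a stereocentre at a saturated chain carbon is drawn without a configuration in compound 2 and R in compound 4

None of the three measured steps bears on this change: each of them swaps one group for another, and none of them changes only a stereo element. The atoms and bonds of compound 2 and compound 4 are the same. For the measured compounds named here, with no measured step of this kind to lean on, no step beyond the scatter is expected for compound 4 in this assay, though the range must be kept wide because a single drawn configuration may sit on either side of the undrawn one. Compound 4 is therefore estimated at 50 nM, between 22 nM and 120 nM, which means an expected step of a 1.1-fold lower number from compound 2 to compound 4 (0.04 log units; within the scatter).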

Compound 4, concentration for 50% growth inhibition: 63 nM
Compound 4: middle estimate off by 1.3-fold (0.10 log units), on the low side, and the stated range covers the measured number.
By their numbers in this assay, from the lowest: compounds 2, 4 and 3 (each within the scatter of the next); then compound 1.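

In this assay, for the compounds shown here, drawing the stereocentre at the saturated chain carbon as R gives a number within the scatter of the undrawn form (a 1.1-fold higher number from compound 2 to compound 4 (0.06 log units; within the scatter)), the first evidence on a change of stereo element alone at this place. The defined compound also keeps the standing of the 2-amino-1-hydroxyethyl group: it remains within the scatter of the oxazolidinone compound (a 1.3-fold lower number from compound 3 to compound 4 (0.10 log units; within the scatter)), and the large step from the trifluoromethyl compound survives with the configuration drawn (an 11-fold lower number from compound 1 to compound 4 (1.04 log units; beyond the scatter)). This agreement has a limit, since the composition of the undrawn form is not given and the comparison cannot separate the R form from whatever that form contains: the fact that one of compounds 2 and 4 is drawn with a defined configuration and the other without, at the place where they differ.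

The compounds shown leave open how the S form of the 2-amino-1-hydroxyethyl group reads, and so whether the configuration at this carbon matters at all in this growth read-out. They also leave open how a dimethylamine, a carboxylic acid or a longer chain carrying the amine would read at the same place on the shared core.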